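The source may hold more compounds than are shown below. What is called first, only, known or untested is meant among the compounds shown, and "the series" means these compounds.

Compound 1 `Cc1cc(NCc2ncccn2)n2nc(C)c(-c3ccccc3)c2n1` is the reference point. In a physicochemical assay for solubility, read by HPLC, using the shake flask method, measured as kinetic solubility, with a stated time of 2 h, at pH 7.4 (a higher number here means a more soluble compound, a lower number a less soluble compound), compound 1 gives 37900 nM. Compound 2 `Cc1cc(NCc2ncc[nH]2)n2nc(C)c(-c3ccccc3)c2n1` reaches only a limit of the assay, and in this assay compound 2 gives < 5000 nM, a limit rather than a number. The step of an at least 7.5-fold lower number from compound 1 to compound 2 (0.87 log units; beyond the scatter) is therefore known only as a lower bound, resting on (the limit of < 5000 nM in this assay, at which 1 of the 2 values shown sits). Compound 3 `Cc1cc(NCC2CCCCN2)n2nc(C)c(-c3ccccc3)c2n1` carries the change (piperidin-2-yl in place of 1H-imidazol-2-yl on a saturated chain carbon bound to a nitrogen on an aromatic ring). For the measured compounds named here, only that single measured step bears on this new change, and it points in the other direction from compound 2. For compound 3 the expected result in this assay is 30000 nM, within a range from 5000 nM to 150000 nM, an estimated step of an at least 6.0-fold higher number from compound 2 to compound 3 (0.77 log units; beyond the scatter).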

Compound 3, solubility: 189000 nM
For compound 3 the middle estimate is 6.3-fold (0.80 log units) below the measured one; the measured number lies above the stated range.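

At this place, on a saturated chain carbon bound to a nitrogen on an aromatic ring, the non-aromatic piperidin-2-yl now stands above both aromatic rings in this assay. Against pyrimidin-2-yl, with both ends real numbers, the result is a 5.0-fold higher number from compound 1 to compound 3 (0.70 log units; beyond the scatter). Against 1H-imidazol-2-yl, the result is an at least 37-fold higher number from compound 2 to compound 3 (1.57 log units; beyond the scatter), a lower bound only, since one end is a limit: the limit of < 5000 nM in this assay, at which 1 of the 3 values shown sits.

The compounds shown leave open how a morpholin-2-yl group or an open-chain amine would read at this place.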